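The source may hold more compounds than are shown below. What is called first, only, known or untested is meant among the compounds shown, and "the series" means these compounds.

Of the compounds shown here, three have been measured in an assay on isolated protein for inhibition of Monoglyceride lipase (Mus musculus), with a stated time of 30 min; on this read-out lower numbers stand for stronger inhibition and higher numbers for weaker inhibition. Compound 1 `COc1ccccc1-c1cccc(N2CC(N3CCN(c4ncccn4)CC3)CC2=O)c1` gives 85 nM. Compound 2 `COc1cccc(-c2cccc(N3CC(N4CCN(c5ncccn5)CC4)CC3=O)c2)c1` gives 39 nM; the difference between the two, (3-methoxyphenyl in place of 2-methoxyphenyl on an aromatic carbon), produced a 2.2-fold lower number from compound 1 to compound 2 (0.34 log units; beyond the scatter), a step that lies beyond the usual scatter. Compound 3 `COc1ccccc1-c1ccc(N2CC(N3CCN(c4ncccn4)CC3)CC2=O)cc1` gives 72 nM, a value that sits within the scatter of both compound 1 and compound 2, so nothing separates it from either of them on this read-out. How the core of compound 3 differs from the core of compound 1 is not broken down here.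

Compound 4 `COc1cccc(-c2ccc(N3CC(N4CCN(c5ncccn5)CC4)CC3=O)cc2)c1` has not yet been measured. It differs from compound 3 by 3-methoxyphenyl in place of 2-methoxyphenyl on an aromatic carbon, the same kind of change as that seen between compound 1 and compound 2, though the place is not identical: in compound 4 the aromatic carbon is para to a large group, whereas in compound 2 it is meta to a large group. Because a 2.2-fold lower number from compound 1 to compound 2 (0.34 log units; beyond the scatter) was observed for the same kind of change, the step from compound 3 to compound 4 is expected to be a 2.0-fold lower number from compound 3 to compound 4 (0.30 log units; within the scatter), allowing for the altered surroundings of the place. Compound 4 is therefore estimated to give 36 nM, most likely between 18 nM and 75 nM, pending the actual measurement in this assay.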

Compound 4, half-maximal inhibitory concentration: 20 nM
Compound 4: middle estimate off by 1.8-fold (0.26 log units), on the high side; low and high end bracket the measured number.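

In this assay, 3-methoxyphenyl in place of 2-methoxyphenyl again gave a lower number, with a 3.6-fold lower number from compound 3 to compound 4 (0.56 log units; beyond the scatter). Set beside the earlier case, the two steps run the same way and their sizes cannot be told apart: the same change on two cores in this assay, a 2.2-fold lower number (0.34 log units; beyond the scatter) from compound 1 to compound 2 and a 3.6-fold lower number (0.56 log units; beyond the scatter) from compound 3 to compound 4, 1.7-fold (0.22 log units) apart, within the scatter of two such steps. On these two cores, then, the change carries over in direction and, within the scatter, in size, but two cores are a small sample: they do not show that it would hold on a more distant core, and they do not explain why the number falls.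

From the compounds shown here alone, all four compounds carry a methoxy group on the aromatic ring that changes, so it remains open what a hydroxyl group, a chlorine atom or an ethoxy group would do at the same place. Going by these compounds, it is also open whether the same step would appear on the enzyme of another species.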